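Chloro to Amino on the Shared Core

The source may report more compounds than this note shows. Statements on the series, on what has been measured and on what is new or still open speak of the compounds shown alone.

Compound 1 `Nc1nn(C(=O)Nc2ccc(Cc3ccccc3)cc2)c2ccccc12` and compound 2 `Nc1nn(C(=O)Nc2ccc(Cc3ccccc3)cc2)c2ccc(Cl)cc12` share one core and differ at a single aromatic carbon. In a functional assay on SF-539 cells (Homo sapiens) for antiproliferative activity, read by sulforhodamine B assay, with a stated time of 48 h (a higher number here means that more compound is tolerated, a lower number that less compound is tolerated), compound 1 gives only a limit of the assay, > 100000 nM. Compound 2 gives 38800 nM. The step of an at least 2.5-fold lower number from compound 1 to compound 2 (0.41 log units; beyond the scatter) shows that the chloro lowered the number, though because one of the two values sits at the assay limit of > 100000 nM in this assay, at which 1 of the 2 values shown sits, the true size of that step is not known. Compound 2 thus holds the only real number shown, the other value being a limit.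

Compound 3 `Nc1ccc2c(c1)c(N)nn2C(=O)Nc1ccc(Cc2ccccc2)cc1` changes this same carbon: amino in place of chloro on an aromatic carbon. Among the compounds with values here, the one measured step concerns hydrogen against chloro and bears on compound 3 only indirectly, giving no direction for an amino group. Compound 3 is therefore expected to land near compound 2, a step of a 1.5-fold higher number from compound 2 to compound 3 (0.19 log units; within the scatter), within the scatter. The estimate for compound 3 is 60000 nM, between 25000 nM and 150000 nM.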

Compound 3, concentration lethal to 50% of the cells: 51800 nM
For compound 3 the middle estimate is 1.2-fold (0.06 log units) above the measured one; measured number inside the range.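

Chloro and amino cannot be told apart at this aromatic carbon in this assay: the step of a 1.3-fold higher number from compound 2 to compound 3 (0.13 log units; within the scatter) lies within the scatter, even though amino brings a hydrogen-bond donor and acceptor that chloro lacks. Compound 3 now gives a second real number on the shared core, so the earlier reading no longer rests on chloro alone. The step of an at least 1.9-fold lower number from compound 1 to compound 3 (0.28 log units; that floor lies within the scatter) is less clear, since its floor lies within the scatter, and the amino group cannot be said to differ from hydrogen here, because the true size of this step is unknown: the limit of > 100000 nM in this assay, at which 1 of the 3 values shown sits.

Going by these compounds, whether a methoxy group, a carboxylic acid or a longer chain on this carbon would move the number beyond the scatter remains open. So does whether amino and chloro would stay this close in other cell lines.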